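The compounds below may be only part of what the source reports. "The series", "measured", "known", "first", "only" and "open" are said of these compounds alone.

Of the compounds shown here, three of one family have been measured in a functional assay on HT-1080 cells (Homo sapiens) for antiproliferative activity, read by sulforhodamine B assay, with a stated time of 48 h; on this read-out higher numbers stand for weaker inhibition and lower numbers for stronger inhibition. Compound 1 `CCC(=O)Nc1ccc(S(=O)(=O)Oc2ccccc2C(C)C)cc1` gives 2100 nM in this assay, the second highest of the three numbers. Compound 2 `CCC(=O)Nc1ccc(S(=O)(=O)Oc2ccccc2I)cc1` gives 7200 nM in this assay, and compound 3 `O=C(Nc1ccc(S(=O)(=O)Oc2ccccc2I)cc1)NC1CC1` gives 1300 nM. Two single changes link them: a 3.4-fold higher number from compound 1 to compound 2 (0.54 log units; beyond the scatter), and a 5.5-fold lower number from compound 2 to compound 3 (0.74 log units; beyond the scatter). Compound 4 `CC(C)c1ccccc1OS(=O)(=O)c1ccc(NC(=O)NC2CCCC2)cc1` has not yet been measured. It differs from compound 1 in one place: cyclopentylamino in place of ethyl on a carbonyl carbon. The closest guide is the change from compound 2 to compound 3, where an amino ring also replaced the ethyl on the carbonyl carbon and the number fell, a 5.5-fold lower number from compound 2 to compound 3 (0.74 log units; beyond the scatter). The same direction is expected for compound 4, with a cyclopentylamino rather than a cyclopropylamino group leaving the exact size open, so a step of roughly similar size is estimated, a 4.2-fold lower number from compound 1 to compound 4 (0.62 log units; beyond the scatter). Compound 4 is therefore expected to give about 500 nM in this assay, most likely between 150 nM and 1600 nM.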

Compound 4, half-maximal inhibitory concentration: 3900 nM
Compound 4: the middle estimate sits 7.8-fold (0.89 log units) below what was measured; the whole stated range lies below it.
By their numbers in this assay, from the lowest: compounds 3, 1, 4 and 2 (each within the scatter of the next, the first and the last beyond it).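

On the isopropyl compounds, putting an amino ring on this carbonyl carbon does not by itself lower the number in this assay: cyclopentylamino, with its six heavy atoms against two for ethyl, gives (a 1.9-fold higher number from compound 1 to compound 4 (0.27 log units; within the scatter)). The earlier fall on the iodo compounds (a 5.5-fold lower number from compound 2 to compound 3 (0.74 log units; beyond the scatter)) therefore does not carry over to this change, which also shows that a ring-bearing group at this place can leave the number within the scatter. No measurement shown gives a reason for this contrast.

From the compounds shown here alone, the two steps differ both in the entering ring and in the group kept at the other end of the molecule, so it remains open which of these matters. Also open, going by these compounds, is how a cyclohexylamino group or an open-chain methylamino group would behave at this carbonyl carbon.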